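A few compounds are considered here, and "the series" means these few. Any claim that something is new, unique, unknown or untested is made for them only; others in the source may bear on it.

Working notes, values in a functional assay on HL-60 cells (Homo sapiens) for inhibition, read by MTT assay, with a stated time of 72 h; on this read-out lower numbers stand for stronger inhibition and higher numbers for weaker inhibition:
- compound 1 `COc1cccc(N2CCN(C(=O)c3oc(C(F)(F)F)nc3-c3cccc(F)c3)CC2)c1`: "not active" (no number reported)
- compound 2 `Cc1nc(-c2ccccc2)c(C(=O)N2CCN(c3cccc(Cl)c3)CC2)o1`: 39.2 nM
- compound 3 `Cc1nc(-c2ccccc2)c(C(=O)N2CCN(c3cccc(Cl)c3Cl)CC2)o1`: 133 nM
- compound 4 `Cc1nc(-c2ccc(F)cc2)c(C(=O)N2CCN(c3cccc(Cl)c3)CC2)o1`: not yet measured

Compound 2 holds the lower of the two numbers available in this assay, and compound 1 offers no number for comparison. The next compound, compound 4, carries one change from compound 2: fluoro in place of hydrogen on an aromatic carbon. This is fluoro in place of hydrogen on an aromatic carbon, or phenyl to 4-fluorophenyl.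

Within the data shown here, only one measured step bears on this change, and only loosely: a 3.4-fold higher number from compound 2 to compound 3 (0.53 log units; beyond the scatter). That step is a modest one, with chloro in place of hydrogen at another place in the molecule. Among the measured compounds shown here, no measured step shows fluoro in place of hydrogen, and none shows a change on this phenyl. A small upward move is therefore expected, most likely within the scatter, and a larger move in either direction cannot be excluded. The estimate is a 1.3-fold higher number from compound 2 to compound 4 (0.11 log units; within the scatter).

For compound 4 the expected value is 50 nM, with an expected range of 15 nM to 160 nM.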

Compound 4, half-maximal inhibitory concentration: 40.1 nM
The estimate for compound 4 lay 1.2-fold (0.10 log units) above the measured number; the range from low to high includes it.
By their numbers in this assay, from the lowest: compounds 2 and 4 (each within the scatter of the next); then compound 3.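

In this assay, fluoro in place of hydrogen on the phenyl, para to a large group, gives a 1.0-fold higher number from compound 2 to compound 4 (0.01 log units; within the scatter). Among these compounds, this is the first reading of a change on this phenyl, and unlike a 3.4-fold higher number from compound 2 to compound 3 (0.53 log units; beyond the scatter), which comes from a chloro at another place in the molecule, it stays within the scatter, so the number does not separate the 4-fluorophenyl from the phenyl. No available measurement explains this result.

Still open, as far as these compounds go, is whether a larger group at this position, such as methoxy, trifluoromethyl or a dimethylamino group, would also leave the number within the scatter of compound 2. Compound 1 differs from compound 2 in more than one place, so the contribution of its trifluoromethyl group cannot be read on its own.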